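Isopropylcarbonyl to tert-butoxycarbonyl on the benzothiophene-urea piperidine

The source may report more compounds than this note shows. Statements on the series, on what has been measured and on what is new or still open speak of the compounds shown alone.

Compound 1 `CC(=O)N1CCC(C(=O)N2CCC(N3CCN(C(=O)c4cc(-c5ccc(C)cc5)nc(-c5ccc(C)cc5)c4)CC3)CC2)CC1` gives 343 nM in a functional assay on HepG2 cells (Homo sapiens) for inhibition, read by scintillation counting, with a stated time of 2 h; a lower number here means a stronger inhibitor, a higher number a weaker inhibitor. Compound 2 `CCNC(=O)Nc1sc2ccccc2c1C(=O)N1CCN(C2CCN(C(=O)C(C)C)CC2)CC1` carries a different shared core, and in this assay compound 2 gives "not determined" (no result reported), so it has no number in this assay; it stands only as the reference point for the change below. Compound 3 `CCNC(=O)Nc1sc2ccccc2c1C(=O)N1CCN(C2CCN(C(=O)OC(C)(C)C)CC2)CC1` differs from compound 2 by tert-butoxy in place of isopropyl on a carbonyl carbon. With no measured step of this kind in the series, the change from compound 2 to compound 3 is expected to be small in this assay, in no settled direction, within the usual scatter. For compound 3 the estimated value in this assay is 400 nM, with a range from 80 nM to 3000 nM.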

Compound 3, half-maximal inhibitory concentration: 79 nM
Beside the measured number, compound 3's estimate is 5.1-fold (0.70 log units) above it; measured number outside the range, below it.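

Among these compounds, with compound 2 carrying no number in this assay, no step to compound 3 at 79 nM can be read. From the compounds shown here alone, the effect of isopropylcarbonyl to tert-butoxycarbonyl on inhibition stays open, and no supporting evidence bears on this result.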